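Methoxy in place of fluoro: compound 1 to compound 4

A few compounds are considered here, and "the series" means these few. Any claim that something is new, unique, unknown or untested is made for them only; others in the source may bear on it.

compound 1 `CC1(/C=C/c2ccc(F)cc2)C=CC(=O)O1` - 101000 nM
compound 2 `COc1ccc(/C=C/C2(C)C=CC(=O)O2)c(OC)c1OC` - 132000 nM
compound 3 `CC1(/C=C/c2cccc(O)c2)C=CC(=O)O1` - 196000 nM

In a functional assay on 786-0 cells (Homo sapiens) for inhibition, read by sulforhodamine B assay, with a stated time of 48 h (a lower number here means a stronger inhibitor of growth, a higher number a weaker inhibitor of growth), the three measured values lie within the scatter of each other, so compound 1 stands level with compound 2 and compound 3 and holds no separate place among them.

The next compound for testing is compound 4 `COc1ccc(/C=C/C2(C)C=CC(=O)O2)cc1`, which differs from compound 1 in one place (methoxy in place of fluoro on an aromatic carbon). Methoxy stands in place of fluoro on an aromatic carbon of a six-membered aromatic ring of carbon only, para to a group of 9 heavy atoms.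

Within the data shown here, no two measured compounds differ in only one place, so the data offer no direct precedent for this change. The closest evidence is compound 2, which also carries methoxy groups on its aromatic ring. Compound 2 gives 132000 nM and stands level with compound 1 (101000 nM).

No step beyond the scatter is therefore expected in this assay, and no direction can be favoured with confidence. The change expected is a 1.3-fold higher number from compound 1 to compound 4 (0.11 log units; within the scatter) and it is estimated to stay within the scatter. The estimate for compound 4 is 130000 nM (expected range 70000 nM to 240000 nM).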

Compound 4, concentration for total growth inhibition: > 1000000 nM
Compound 4 gave a limit, no number (the forecaster's own chance of this, stated with the estimate: 10%); middle value at least 7.6-fold (0.88 log units) from the limit.
By their numbers in this assay, from the lowest: compounds 1, 2 and 3 (each within the scatter of the next). At a limit, above all of these: compound 4.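

In this assay compound 4 gives > 1000000 nM, which is a limit of the assay and not a number. Methoxy in place of fluoro on an aromatic carbon, para to a group of 9 heavy atoms, gives an at least 9.9-fold higher number from compound 1 to compound 4 (0.99 log units; beyond the scatter), the first step in the series between compounds that differ in one place, and it shows that a single change at this position can carry a compound well beyond the scatter, which the three level values of the earlier compounds could not show. The full size of this step cannot be read, only its lower bound: the limit of > 1000000 nM in this assay, at which 1 of the 4 values shown sits.

One pair cannot tell whether the step follows from the loss of fluoro or from the arrival of methoxy, nor whether the same exchange would have a similar effect on another aromatic carbon. The compounds shown also leave open how this position responds to other groups, such as chloro, an amine or a carboxylic acid on the same aromatic carbon, and whether any of them gives a lower number than compound 1.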